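The source may hold more compounds than are shown below. What is called first, only, known or untested is meant among the compounds shown, and "the series" means these compounds.

Measured compounds:

Compound 1 `COc1cc(C(=O)/C=C\Nc2ccc(-c3nc4cc(OC)c(OC)c(OC)c4s3)cc2C)cc([N+](=O)[O-])c1OC` — in a functional assay on MDA-MB-231 cells (Homo sapiens) for antiproliferative activity, read by sulforhodamine B assay, with a stated time of 48 h (on this read-out lower numbers stand for stronger inhibition and higher numbers for weaker inhibition), compound 1 gives 12800 nM.
Compound 2 `COc1cc(C(=O)/C=C\Nc2ccc(-c3nc4cc(OC)c(OC)c(OC)c4s3)cc2)cc([N+](=O)[O-])c1OC` — in this assay compound 2 gives 9800 nM.
Compound 3 `COc1ccc2nc(-c3ccc(N/C=C\C(=O)c4cc(OC)c(OC)c(OC)c4Br)c(C)c3)sc2c1` — in this assay compound 3 gives 9400 nM.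

The three measured compounds all lie within the usual scatter of one another in this assay, so none is set apart from the others. From compound 1 to compound 2 the change is hydrogen in place of methyl on an aromatic carbon, and the step that goes with it is a 1.3-fold lower number from compound 1 to compound 2 (0.12 log units; within the scatter).

Compound 4 `COc1ccc2nc(-c3ccc(N/C=C\C(=O)c4cc(OC)c(OC)c(OC)c4Br)cc3)sc2c1` is not yet measured. It differs from compound 3 by hydrogen in place of methyl on an aromatic carbon. This is the same kind of change as that from compound 1 to compound 2, though the two places are not described in the same words: in compound 3 the group that leaves sits meta to a 6-methoxy-1,3-benzothiazol-2-yl group, whereas in compound 1 it sits meta to a large group. How the core of compound 3 differs from the core of compound 1 is not broken down here.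

The expectation for compound 4 rests on the single earlier occurrence of the change, the step of a 1.3-fold lower number from compound 1 to compound 2 (0.12 log units; within the scatter), which stayed within the scatter. The same kind of change is therefore expected to give a step of about a 1.3-fold lower number from compound 3 to compound 4 (0.10 log units; within the scatter) from compound 3 to compound 4 in this assay. Compound 4 is accordingly estimated at 7500 nM in this assay, with a range from 4000 nM to 14000 nM.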

Compound 4, half-maximal inhibitory concentration: 11100 nM
Beside the measured number, compound 4's estimate is 1.5-fold (0.17 log units) below it, and the stated range covers the measured number.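

In this assay, hydrogen in place of methyl on an aromatic carbon gives a 1.2-fold higher number from compound 3 to compound 4 (0.07 log units; within the scatter), and set beside the earlier occurrence of the change, the two steps do not differ: the same change on two cores in this assay, a 1.3-fold lower number (0.12 log units; within the scatter) from compound 1 to compound 2 and a 1.2-fold higher number (0.07 log units; within the scatter) from compound 3 to compound 4, 1.5-fold (0.19 log units) apart, within the scatter of two such steps. On these two cores the change therefore carries over as a step within the scatter, and nothing in the pairs points to a dependence on the core. This does not show that the change has any effect on the read-out in either direction, and with both steps inside the scatter, the pairs do not test whether a change with a clear effect would carry from one core to the other; two pairs also give no basis for extending the result to further cores in the series.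

The compounds shown leave open whether another group in the place of the methyl, such as a methoxy group, a chlorine atom or an amine, would move the number beyond the scatter on either core. They also leave open which of the parts in which the two cores differ matters for the read-out, as no pair shown separates those parts.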